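The compounds below may be only part of what the source reports. "The series", "measured", "known", "first", "only" and "open" are said of these compounds alone.

Compound 1 `CCOC(=O)/C=C/c1ccncc1-c1ccc2[nH]ccc2c1` is one of three members of the series with a number in a functional assay on A549 cells (Homo sapiens) for inhibition, read by sulforhodamine B assay, with a stated time of 72 h (a higher number here means a weaker inhibitor of growth, a lower number a stronger inhibitor of growth), where compound 1 gives 7440 nM. Compound 2 `O=C(/C=C/c1ccncc1-c1ccc2ccccc2c1)NC1CC1` gives 5840 nM in this assay; the two values lie within the scatter of each other, so neither can be ranked over the other. Compound 3 `NNC(=O)CCc1ccncc1-c1ccc2ccccc2c1` reaches only the limit > 10000 nM in this assay. Within the data shown here, the one measured step, an at least 1.7-fold higher number from compound 2 to compound 3 (0.23 log units; that floor lies within the scatter), is a floor rather than a number because the limit of > 10000 nM in this assay, at which 1 of the 3 values shown sits, is where compound 3 sits; it also exchanges a 2-(cyclopropylcarbamoyl)ethenyl for a 2-(aminocarbamoyl)ethyl and has nothing in common with the change now in view.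

Compound 4 `O=C(O)/C=C/c1ccncc1-c1ccc2[nH]ccc2c1` differs from compound 1 by hydrogen in place of ethyl on an oxygen next to a carbonyl group, that is, 2-(ethoxycarbonyl)ethenyl becomes 2-carboxyethenyl. Among the measured compounds shown here, no measured step touches this oxygen, so the expectation rests on compound 1 alone. Compound 4 is therefore estimated near or somewhat weaker than compound 1, a step of a 1.2-fold higher number from compound 1 to compound 4 (0.08 log units; within the scatter), with a real chance that only a limit is returned. For compound 4 the estimate is 9000 nM, within 3000 nM to 30000 nM.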

Compound 4, concentration for 50% growth inhibition: > 10000 nM
Compound 4 ended at the assay's limit; the forecaster's own chance of this, stated with the estimate: 45%; middle value at least 1.1-fold (0.04 log units) away from the limit.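

In this assay compound 4 gives > 10000 nM, which is a limit of the assay and not a number. The exchange of 2-(ethoxycarbonyl)ethenyl for 2-carboxyethenyl can therefore be read only as a floor, an at least 1.3-fold higher number from compound 1 to compound 4 (0.12 log units; that floor lies within the scatter), so hydrogen on this oxygen shows no lower number than ethyl, while the true size of the step stays unread. Compound 4 also adds to the values that give no number: the limit of > 10000 nM in this assay, at which 2 of the 4 values shown sit.

Open, going by these compounds, is whether any change on this oxygen can lower the number in this assay, for instance a methyl group or a longer chain such as butyl in place of ethyl. Also open is how the ethyl ester compares with an amide on one and the same core, since the compounds shown offer no such single-place pair.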